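The compounds below may be only part of what the source reports. "The series", "measured", "known", "first", "only" and "open" are said of these compounds alone.

Measured compounds in a functional assay on ACHN cells (Homo sapiens) for inhibition, read by sulforhodamine B assay, with a stated time of 48 h; on this read-out lower numbers stand for stronger inhibition of growth and higher numbers for weaker inhibition of growth:

compound 1, `COc1cc(-c2nn(-c3cccc(NC(=O)c4ccc(Cl)c(C(F)(F)F)c4)c3)cc2-c2ccncc2)ccc1Cl` — 2730 nM
compound 2, `O=C(Nc1cccc(-n2cc(-c3ccncc3)c(-c3ccc(Cl)c(O)c3)n2)c1)Nc1cc(C(F)(F)F)cc(C(F)(F)F)c1` — 624 nM

Of the two numbers, compound 1 gives the higher one in this assay, with 2730 nM. Compound 2 gives 624 nM, a lower number, and the gap between the two lies beyond the usual scatter of this read-out. For the measured compounds named here, compound 2 differs from compound 1 in more than one place, so no single step between them can be drawn out.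

Compound 3, `COc1cc(-c2nn(-c3cccc(NC(=O)Nc4cccc(C(F)(F)F)c4)c3)cc2-c2ccncc2)ccc1Cl`, is the next compound to be measured. It differs from compound 1 at one place only: (3-(trifluoromethyl)phenyl)amino in place of 4-chloro-3-(trifluoromethyl)phenyl on a carbonyl carbon. Compound 2, which gives the lower number of the two measured, also carries a (3-(trifluoromethyl)phenyl)amino-type arrangement on its carbonyl carbon, though alongside other changes, so the direction this single change takes is not fixed by the shown values. On that basis the step from compound 1 to compound 3 is expected to be a modest move toward a lower number, a 2.1-fold lower number from compound 1 to compound 3 (0.32 log units; beyond the scatter), though a step within the scatter would not surprise. Compound 3 is therefore estimated at 1300 nM, with a range from 400 nM to 4000 nM.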

Compound 3, concentration for 50% growth inhibition: 656 nM
Beside the measured number, compound 3's estimate is 2.0-fold (0.30 log units) above it; the range from low to high includes it.
By their numbers in this assay, from the lowest: compounds 2 and 3 (each within the scatter of the next); then compound 1.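

In this assay, for the compounds shown here, putting (3-(trifluoromethyl)phenyl)amino in place of 4-chloro-3-(trifluoromethyl)phenyl on a carbonyl carbon gives a 4.2-fold lower number from compound 1 to compound 3 (0.62 log units; beyond the scatter) and is the first single-place step available, showing that the number responds to a change at this position by more than the scatter. The two groups match in heavy-atom count and each holds one six-membered aromatic ring of carbon only, but the exchange removes the chlorine and brings in a nitrogen with one hydrogen-bond donor, so the step belongs to these changes taken together. No measurement shown gives a reason for this step.

The compounds shown leave open how much of the step follows from the loss of the chlorine and how much from the entry of the nitrogen, since both occur in the same exchange. From the compounds shown here alone, a 4-chloro-3-(trifluoromethyl)phenylamino group or a plain 3-(trifluoromethyl)phenyl group on the same carbonyl carbon would separate the two, and how a methylamino group or another small amine would fare there also remains unknown.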